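Selenium-bearing acyl amidines: from benzyl to methyl on selenium

This account rests on a few compounds, and the source may have more. Where it says the series, first, only, none or still open, it means among the compounds named here.

Measured so far:
Compound 1, `CS/C(=N\C(=O)c1csc([N+](=O)[O-])c1)NC(=O)c1csc([N+](=O)[O-])c1`: 44700 nM
Compound 2, `CS/C(=N\C(=O)c1cccs1)NC(=O)c1cccs1`: 44500 nM
Compound 3, `O=C(/N=C(/NC(=O)c1csc([N+](=O)[O-])c1)[Se]Cc1ccccc1)c1csc([N+](=O)[O-])c1`: 24400 nM

All three numbers come from a functional assay on MCF7 cells (Homo sapiens) for cytotoxicity, read by MTT assay, with a stated time of 72 h; a lower number here means a stronger inhibitor of growth, a higher number a weaker inhibitor of growth. Compound 3 carries the smallest figure of the three, but both its distance to compound 2 and the step of a 1.8-fold lower number from compound 1 to compound 3 (0.26 log units; within the scatter) lie within the scatter, so the three compounds are not told apart by these data.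

The next compound, compound 4, is `C[Se]/C(=N\C(=O)c1csc([N+](=O)[O-])c1)NC(=O)c1csc([N+](=O)[O-])c1`. It differs from compound 3 in one place: hydrogen in place of phenyl on a saturated chain carbon bound to a selenium atom. Compound 4 thus sits between compound 1 and compound 3: it keeps the selenium of compound 3 but shrinks the group on it to the methyl of compound 1.

Among the measured compounds shown here, only one measured step bears on this change, a 1.8-fold lower number from compound 1 to compound 3 (0.26 log units; within the scatter), which swapped sulfur-methyl for selenium-benzyl and stayed within the scatter. Removing the phenyl again while keeping selenium is unlikely to move the number beyond the scatter in either direction; the estimate is placed between compound 1 and compound 3. Compound 4 is therefore expected to give 32000 nM, with a range from 13000 nM to 80000 nM. The expected step is then a 1.3-fold higher number from compound 3 to compound 4 (0.12 log units; within the scatter).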

Compound 4, concentration for 50% growth inhibition: 0.76 nM
The estimate for compound 4 lay 42000-fold (4.62 log units) above the measured number, outside the stated range (below it).
By their numbers in this assay, from the lowest: compound 4; then compounds 3, 2 and 1 (each within the scatter of the next).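

In this assay, turning benzyl into methyl on selenium gives a 32000-fold lower number from compound 3 to compound 4 (4.51 log units; beyond the scatter), and exchanging sulfur for selenium with the methyl kept gives a 59000-fold lower number from compound 1 to compound 4 (4.77 log units; beyond the scatter), so both the atom and the group on it matter greatly here. The earlier step, a 1.8-fold lower number from compound 1 to compound 3 (0.26 log units; within the scatter), changed both at once and stayed within the scatter, which hid how much each one can matter: among these compounds only selenium carrying methyl stands apart, while sulfur carrying methyl in compound 1 and selenium carrying benzyl in compound 3 do not. No measurement among these data accounts for the size of these steps.

Going by these compounds, whether an ethyl group or a longer chain on selenium keeps a number this low, or whether the effect belongs to methyl alone, remains open. Also open, on these data alone, are what an amine or a carboxylic acid at the end of such a chain would do, and whether the nitro groups still count once selenium carries methyl.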